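One Methyl Removed: What Growth Inhibition to Expect

The compounds below may be only part of what the source reports. "The series", "measured", "known", "first", "only" and "open" are said of these compounds alone.

Measured in a functional assay on DU-145 cells (Homo sapiens) for inhibition, read by sulforhodamine B assay, with a stated time of 48 h; a higher number here means a weaker inhibitor of growth, a lower number a stronger inhibitor of growth:
compound 1 `COc1cc(-c2nn(-c3cccc(NC(=O)Nc4cc(C(F)(F)F)cc(C(F)(F)F)c4)c3)cc2-c2ccncc2)ccc1Cl` gives 5040 nM
compound 2 `COc1cc(-c2nn(-c3cccc(NC(=O)Nc4ccc(Cl)c(Cl)c4)c3)cc2-c2ccncc2)ccc1Cl` gives 34200 nM
compound 3 `O=C(Nc1cccc(-n2cc(-c3ccncc3)c(-c3ccc(Cl)c(O)c3)n2)c1)Nc1ccc(Cl)c(Cl)c1` gives a limit of the assay, > 32500 nM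

Compound 1 has the lower of the two numbers that were read, and its gap to compound 2 lies beyond the usual scatter. The difference between the cores of compound 1 and compound 2 is not broken down here. The step that the limit leaves unreadable from compound 2 to compound 3 cannot be read because of the limit of > 32500 nM in this assay, at which 1 of the 3 values shown sits.

Compound 4 `O=C(Nc1cccc(-n2cc(-c3ccncc3)c(-c3ccc(Cl)c(O)c3)n2)c1)Nc1cc(C(F)(F)F)cc(C(F)(F)F)c1` has not been measured. It differs from compound 1 by hydrogen in place of methyl on an oxygen on an aromatic ring, the same change as hydrogen in place of methyl on an oxygen on an aromatic ring seen between compound 2 and compound 3. The step is expected to be a 1.8-fold higher number from compound 1 to compound 4 (0.25 log units; within the scatter), a cautious guess because a step that the limit leaves unreadable from compound 2 to compound 3 gives no readable size. In this assay compound 4 is expected to give about 9000 nM, estimated between 2500 nM and 33000 nM.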

Compound 4, concentration for total growth inhibition: 5620 nM
For compound 4 the middle estimate is 1.6-fold (0.20 log units) above the measured one, within the range that was stated.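

In this assay, the change from methoxy to hydroxy gives a 1.1-fold higher number from compound 1 to compound 4 (0.05 log units; within the scatter), so compound 1 and compound 4 cannot be told apart. Compound 3 gives > 32500 nM, which is a limit of the assay and not a number, and the same change from compound 2 to compound 3 cannot be read. This single readable step shows that the hydroxy group keeps the value of compound 1 on that core, but it does not show that the result carries over to the core of compound 2.

The compounds shown leave open how other groups on that oxygen would read. An ethyl group or a longer chain there, or an amine in place of the methoxy, could show how much change this spot accepts.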